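The source may report more compounds than this note shows. Statements on the series, on what has been measured and on what is new or still open speak of the compounds shown alone.

Compound 3, `CCCSc1nc(N/N=C(\C)c2ccccc2O)c2nnn(Cc3ccccc3)c2n1`, gives 2310 nM in a functional assay on MGC-803 cells (Homo sapiens) for antiproliferative activity, read by MTT assay, with a stated time of 72 h; on this read-out lower numbers stand for stronger inhibition and higher numbers for weaker inhibition. Of the two numbers in hand it stands lowest; the nearest is compound 1, `CCCSc1nc(N/N=C(\C)c2ccccc2O)c2nnn(Cc3cccc(Cl)c3)c2n1`, which in this assay gives 6500 nM. Compound 2, `CCCSc1nc(N/N=C/c2cccs2)c2nnn(Cc3ccccc3)c2n1`, reaches only a limit of this assay, > 64000 nM. Going from compound 1 to compound 3, where hydrogen takes the place of chloro on an aromatic carbon, the number falls by a modest amount, a 2.8-fold lower number from compound 1 to compound 3 (0.45 log units; beyond the scatter). The step from compound 2 to compound 3 is far larger, an at least 27-fold lower number from compound 2 to compound 3 (1.44 log units; beyond the scatter), but it concerns a different part of the molecule and does not bear on the change considered here.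

Compound 4, `CCCSc1nc(N/N=C(\C)c2ccccc2O)c2nnn(Cc3ccc(Cl)cc3)c2n1`, has not yet been measured. It differs from compound 3 by chloro in place of hydrogen on an aromatic carbon. Within the data shown here, the only measured step that speaks to a chloro on the benzyl ring is the one from compound 1 to compound 3, where removing chloro lowered the number modestly; returning a chloro to the benzyl ring is therefore expected to raise the number in this assay by a step of similar, modest size. The step from compound 3 to compound 4 is expected to be a 2.2-fold higher number from compound 3 to compound 4 (0.34 log units; beyond the scatter). Compound 4 is estimated at 5000 nM, with a range from 1500 nM to 16000 nM.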

Compound 4, half-maximal inhibitory concentration: 7100 nM
Estimate against measurement, compound 4: 1.4-fold (0.15 log units) below; the range from low to high includes it.
By their numbers in this assay, from the lowest: compound 3; then compounds 1 and 4 (each within the scatter of the next). At a limit, above all of these: compound 2.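

In this assay, placing chloro on the aromatic carbon para to a large group, which turns benzyl into 4-chlorobenzyl, gives a 3.1-fold higher number from compound 3 to compound 4 (0.49 log units; beyond the scatter), so a second chlorinated benzyl compound now joins the first in carrying a higher number than the unsubstituted benzyl compound, and no compound shown goes against this. Moving the chloro from 3-chlorophenyl to 4-chlorophenyl gives a 1.1-fold higher number from compound 1 to compound 4 (0.04 log units; within the scatter), which lies within the scatter, so in this small set the two chloro placements cannot be told apart, and the presence of chloro on the ring matters more here than which of these two places it occupies. Nothing in the available evidence bears on why chloro has this effect at either place.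

The compounds shown leave open whether another group at the same place, such as fluoro, methoxy, or an amine, would also raise the number or would match or improve on compound 3. They also leave open whether the effect of chloro would be the same with a longer chain in place of the propyl thioether of the shared core.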